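The source may hold more compounds than are shown below. What is called first, only, known or untested is meant among the compounds shown, and "the series" means these compounds.

Three compounds have been measured in an ADME assay on MT4 cells (Homo sapiens) for cytotoxicity, read by MTT assay, with a stated time of 96 h; on this read-out higher numbers stand for lower toxicity in this test and lower numbers for higher toxicity in this test:

Compound 1 `CN(C)CCCN(/N=N/c1cc(F)ccc1F)c1cccc(C(F)(F)F)c1` gives 16000 nM.
Compound 2 `c1ccc(/N=N/c2ccc(NC[C@@H]3CCCN4CCCC[C@H]34)c3c2CCCC3)cc1` gives 100000 nM.
Compound 3 `CN(C)CCCN(/N=N/c1ccccc1)c1ccccc1` gives 33000 nM.

Of these three numbers, compound 2 stands highest. Its nearest neighbour is compound 3, whose number is lower by a margin beyond the scatter, and compound 1 lies further still below it. Compound 4 `Fc1ccc(/N=N/c2ccc(NC[C@@H]3CCCN4CCCC[C@H]34)c3c2CCCC3)c(F)c1` is built from compound 2 by one change: 2,4-difluorophenyl in place of phenyl on a double-bonded nitrogen. For the measured compounds named here, no step between two measured compounds isolates this change, so no measured precedent for its size exists. Going by the values given here, compound 1 and compound 3 differ in more than one place, and their two values show only that compound 1 is the lower of the pair. The step from compound 2 to compound 4 is expected to be small, a modest fall in the number that need not exceed the scatter, giving a 1.7-fold lower number from compound 2 to compound 4 (0.22 log units; within the scatter). Compound 4 is therefore estimated at 60000 nM in this assay, within a range of 25000 nM to 150000 nM.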

Compound 4, half-maximal cytotoxic concentration: 51000 nM
The estimate for compound 4 lay 1.2-fold (0.07 log units) above the measured number; the measured number falls inside the stated range.
By their numbers in this assay, from the lowest: compound 1; then compounds 3, 4 and 2 (each within the scatter of the next, the first and the last beyond it).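

In this assay, 2,4-difluorophenyl in place of phenyl on a double-bonded nitrogen gives a 2.0-fold lower number from compound 2 to compound 4 (0.29 log units; within the scatter) and so stays within the scatter. For the compounds shown here, this is the first measure of this change alone, and on this core the two numbers cannot be told apart. Nothing at hand offers an explanation for this result.

Going by these compounds, whether a single fluorine, a methoxy group or a primary amine at this place would give a step beyond the scatter remains open. Also open, on these data alone, is whether the same change would give a similar step on the core of compound 3.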